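Aryl-triazole variation in the spiro series, HUVEC antiproliferation

This account rests on a few compounds, and the source may have more. Where it says the series, first, only, none or still open, it means among the compounds named here.

Measured so far:
compound 1 `N#CC1=C(N)Oc2c(N)cc3nc4ccccc4nc3c2C12C(=O)N(Cc1cnnn1-c1ccccc1Cl)c1ccccc12` — > 50000 nM
compound 2 `Cc1cc(C)cc(-n2nncc2CN2C(=O)C3(C(C#N)=C(N)Oc4c(N)cc5nc6ccccc6nc5c43)c3ccccc32)c1` — > 50000 nM

Two compounds of the series have been run in an ADME assay on HUVEC cells (Homo sapiens) for antiproliferative activity, read by MTT assay, with a stated time of 48 h; a lower number here means a stronger inhibitor, a higher number a weaker inhibitor. For compound 1 the value > 50000 nM is a limit of the assay, not a number. For compound 2 the value > 50000 nM is likewise a limit. The step that the two limits leave unreadable from compound 1 to compound 2 therefore cannot be read; both lie at the limit of > 50000 nM in this assay, at which 2 of the 2 values shown sit. Compound 2 thus stands at the limit, with no measured number to place it against.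

Compound 3 `CCc1cccc(CC)c1-n1nncc1CN1C(=O)C2(C(C#N)=C(N)Oc3c(N)cc4nc5ccccc5nc4c32)c2ccccc21` is not yet measured. It differs from compound 2 by 2,6-diethylphenyl in place of 3,5-dimethylphenyl on an aromatic nitrogen. For the measured compounds named here, the only measured step, from compound 1 to compound 2, also exchanges the aryl group on this aromatic nitrogen and is unreadable, so nothing in the data sets a size or direction for the change to compound 3. With both measured compounds at the limit, the expected step is a step that the limit leaves unreadable from compound 2 to compound 3, which means none beyond the scatter. The estimate for compound 3 in this assay is 60000 nM, between 25000 nM and 150000 nM, most likely reported again as a limit.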

Compound 3, half-maximal inhibitory concentration: > 50000 nM
Compound 3: no number, only a limit (the forecaster's own chance of this, stated with the estimate: 85%); the middle value lies beyond the limit too.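

In this assay compound 3 gives > 50000 nM as a limit of the assay, not a number. For the compounds shown here, no step among compound 1, compound 2 and compound 3 can be read, and all three stand at the same limit: the limit of > 50000 nM in this assay, at which 3 of the 3 values shown sit. The compounds shown leave open whether any aryl group on this aromatic nitrogen gives a measurable value.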